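Swapping tert-butyl for 4-fluorophenyl on a kinase inhibitor

A few compounds are considered here, and "the series" means these few. Any claim that something is new, unique, unknown or untested is made for them only; others in the source may bear on it.

In an assay on BaF3 cells for inhibition of proto-oncogene tyrosine-protein kinase receptor Ret variant V804M (Homo sapiens), read by MTT assay, with a stated time of 48 h (on this read-out lower numbers stand for stronger inhibition of growth and higher numbers for weaker inhibition of growth), compound 1 `CC(C)n1nc(-c2cc(C(C)(C)C)on2)c2c(N)ncnc21` gives 7310 nM. In this assay compound 2 `Nc1ncnc2c1c(-c1cc(C3CC3)on1)nn2C1CCCCC1` gives 2000 nM. Compound 3 `CCCCCCCn1nc(-c2cc(C3CC3)on2)c2c(N)ncnc21` gives > 10000 nM in this assay, which is a limit of the assay rather than a number.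

Compound 1 holds the highest of the two numbers; compound 2 sits at a lower number, beyond the scatter. Compound 4 `CC(C)n1nc(-c2cc(-c3ccc(F)cc3)on2)c2c(N)ncnc21` differs from compound 1 in one place: 4-fluorophenyl in place of tert-butyl on an aromatic carbon. Going by the values given here, the only measured step, an at least 5.0-fold higher number from compound 2 to compound 3 (0.69 log units; beyond the scatter), concerns the group on the aromatic nitrogen, not the carbon of the five-membered ring changed here, so no measured step bears directly on this change. A modest step is therefore expected, estimated as a 2.9-fold lower number from compound 1 to compound 4 (0.47 log units; beyond the scatter). Compound 4 is estimated at 2500 nM, with a range from 500 nM to 10000 nM.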

Compound 4, concentration for 50% growth inhibition: > 10000 nM
Compound 4: no number, only a limit; the forecaster's own chance of this, stated with the estimate: 15%; middle value at least 4.0-fold (0.60 log units) from the limit.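

In this assay, the carbon next to the ring oxygen shows no gain from the larger aromatic group: the change gives an at least 1.3-fold higher number from compound 1 to compound 4 (0.13 log units; that floor lies within the scatter). Compound 4 gives > 10000 nM, which is a limit and not a number. The true size of the step therefore stays unknown, and this ceiling recurs among the compounds: the limit of > 10000 nM in this assay, at which 2 of the 4 values shown sit.

Going by these compounds, whether the fluorine or the six-membered ring matters more remains open, and a plain phenyl at this carbon would separate the two. On these data alone, how an amine or a carboxylic acid would fare here is also open.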